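A few compounds are considered here, and "the series" means these few. Any claim that something is new, unique, unknown or untested is made for them only; others in the source may bear on it.

Measured in a functional assay on CCRF-CEM cells (Homo sapiens), read by MTT assay, with a stated time of 72 h; on this read-out higher numbers stand for weaker inhibition and lower numbers for stronger inhibition:
Compound 1 `CNc1ncnc2c1c(-c1ccccc1)cn2[C@@H]1O[C@H](CO)[C@@H](O)[C@H]1O`: > 20000 nM, a limit.
Compound 2 `Nc1nc(N)c2c(-c3cc4ccccc4o3)cn([C@@H]3O[C@H](CO)[C@@H](O)[C@H]3O)c2n1`: > 20000 nM, a limit.
Compound 3 `COc1nc(N)nc2c1c(-c1ccoc1)cn2[C@@H]1O[C@H](CO)[C@@H](O)[C@H]1O`: > 20000 nM, a limit.

None of the three compounds has a numerical potency, and the overall picture in this assay is the limit of > 20000 nM in this assay, at which 3 of the 3 values shown sit. Compound 3 therefore has no exact position in the series. It shares that limit with the other two compounds, although the three structures differ in several places.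

The next compound is compound 4 `C#Cc1cn([C@@H]2O[C@H](CO)[C@@H](O)[C@H]2O)c2nc(N)nc(OC)c12`, which keeps the rest of compound 3 and changes one group. The change is ethynyl in place of furan-3-yl on an aromatic carbon: ethynyl takes the place of furan-3-yl on an aromatic carbon.

Within the data shown here, no pair of measured compounds differs in only one place, so the data give no direct measure of such a change. The three limits also leave the true starting point open. The most likely outcome is that compound 4 stays at the limit or close to it, with at most a modest shift toward stronger inhibition. The expected change is an at least 1.3-fold lower number from compound 3 to compound 4 (0.12 log units; that floor lies within the scatter), which is only a tentative estimate. For compound 4 the estimated value is 15000 nM, with an expected range from 2000 nM to 40000 nM.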

Compound 4, half-maximal inhibitory concentration: > 100000 nM
Compound 4: only a limit was reported; the forecaster's own chance of this, stated with the estimate: 60%; at least 6.6-fold (0.82 log units) between middle value and limit.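

Compound 3 and compound 4 are both reported only as limits, so the replacement of furan-3-yl by ethynyl gives no readable step between them. The compounds shown leave open where the true potency of each lies, and whether either group on that aromatic carbon gives stronger inhibition than the other.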